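Removing the chloro from the benzoyl group of compound 3

The source may hold more compounds than are shown below. What is called first, only, known or untested is meant among the compounds shown, and "the series" means these compounds.

Measured compounds:
compound 1 `COc1cc(-c2nnc3n2NC(c2cccs2)C(C(=O)c2ccccc2)S3)cc(OC)c1OC`, 69400 nM
compound 2 `COc1cc(-c2nnc3n2NC(c2ccco2)C(C(=O)c2ccc(F)c(F)c2)S3)cc(OC)c1OC`, 93700 nM
compound 3 `COc1cc(-c2nnc3n2NC(c2ccco2)C(C(=O)c2ccc(Cl)cc2)S3)cc(OC)c1OC`, 51400 nM

In a functional assay on A549 cells (Homo sapiens) for cytotoxicity, read by MTT assay, with a stated time of 48 h (a lower number here means a stronger inhibitor, a higher number a weaker inhibitor), compound 3 gives the lowest of the three numbers, though its gaps to compound 1 and compound 2 lie within the usual scatter. Compound 4 `COc1cc(-c2nnc3n2NC(c2ccco2)C(C(=O)c2ccccc2)S3)cc(OC)c1OC` differs from compound 3 by hydrogen in place of chloro on an aromatic carbon. The only measured step on the same ring, a 1.8-fold lower number from compound 2 to compound 3 (0.26 log units; within the scatter), stayed within the scatter, so swapping substituents on this ring has shown no clear effect. Compound 1, which carries the unsubstituted benzoyl group together with a different five-membered ring, also sits close to compound 3. For compound 4 the expected step is therefore a 1.3-fold higher number from compound 3 to compound 4 (0.10 log units; within the scatter), with no change beyond the scatter. Compound 4 is estimated at 65000 nM, in a range from 30000 nM to 140000 nM.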

Compound 4, half-maximal inhibitory concentration: 33400 nM
Compound 4: the middle estimate sits 1.9-fold (0.29 log units) above what was measured; the measured number falls inside the stated range.
By their numbers in this assay, from the lowest: compounds 4, 3, 1 and 2 (each within the scatter of the next, the first and the last beyond it).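

In this assay the loss of the chloro gives a 1.5-fold lower number from compound 3 to compound 4 (0.19 log units; within the scatter) and so stays inside the scatter, yet the plain benzoyl group now separates from the 3,4-difluorophenyl version, with a 2.8-fold lower number from compound 2 to compound 4 (0.45 log units; beyond the scatter) as a modest step. The five-membered ring also counts: furan-2-yl in place of thiophen-2-yl gives a 2.1-fold lower number from compound 1 to compound 4 (0.32 log units; beyond the scatter) and is likewise modest. Nothing measured here explains either step.

As far as these compounds go, it remains open whether an amine or a carboxylic acid on the phenyl ring would move the number further. From the compounds shown here alone, whether the furan-2-yl step holds with other benzoyl groups also remains open.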